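A few compounds are considered here, and "the series" means these few. Any claim that something is new, unique, unknown or untested is made for them only; others in the source may bear on it.

Measured so far in a functional assay on CHO cells for agonist activity at Free fatty acid receptor 1 (Homo sapiens), read by FLIPR and calcium flux; a higher number here means that more compound is needed for the effect, a lower number that less compound is needed:
- compound 1 `Cc1cccc(C)c1-c1cccc(COc2ccc(S(=O)(=O)CC(=O)O)cc2)c1`: 66.1 nM
- compound 2 `O=C(O)CS(=O)(=O)c1ccc(OCc2cccc(-c3ccccc3F)c2)cc1`: 257 nM
- compound 3 `CC(C)c1ccccc1-c1cccc(COc2ccc(S(=O)(=O)CC(=O)O)cc2)c1`: 74.1 nM

Compound 3 stands second highest of the three numbers in this assay; its nearest neighbour is compound 1, with a gap that is within the scatter, and the furthest is compound 2.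

Compound 4 `Cc1ccc(C)n1-c1cccc(COc2ccc(S(=O)(=O)CC(=O)O)cc2)c1` has not been measured. It differs from compound 3 in one place: 2,5-dimethyl-1H-pyrrol-1-yl in place of 2-isopropylphenyl on an aromatic carbon.

Among the measured compounds shown here, two measured steps bear on the group at this position. Exchange of 2,6-dimethylphenyl for 2-isopropylphenyl gives a 1.1-fold higher number from compound 1 to compound 3 (0.05 log units; within the scatter), so these two six-membered groups are interchangeable here. Reduction to 2-fluorophenyl costs, with a 3.9-fold higher number from compound 1 to compound 2 (0.59 log units; beyond the scatter) and a 3.5-fold lower number from compound 2 to compound 3 (0.54 log units; beyond the scatter). For the measured compounds named here, no measured step covers a five-membered ring with a nitrogen at this position. The 2,5-dimethyl-1H-pyrrol-1-yl group keeps two methyl groups as in compound 1 but is a smaller ring. A modest loss is therefore expected for compound 4, smaller than the step from compound 1 to compound 2. The expected step for compound 4 is roughly a 2.0-fold higher number from compound 3 to compound 4 (0.31 log units; beyond the scatter).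

Compound 4 is estimated at 150 nM in this assay, within 50 nM to 500 nM.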

Compound 4, half-maximal effective concentration: 129 nM
Estimate against measurement, compound 4: 1.2-fold (0.07 log units) above, within the range that was stated.
By their numbers in this assay, from the lowest: compounds 1, 3, 4 and 2 (each within the scatter of the next, the first and the last beyond it).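

The 2,5-dimethyl-1H-pyrrol-1-yl group shows that this position, on an aromatic carbon, accepts a five-membered aromatic ring with 1 hetero atom as well as the six-membered aromatic rings of carbon only. In this assay, all three new steps lie within the scatter (a 1.7-fold higher number from compound 3 to compound 4 (0.24 log units; within the scatter); a 2.0-fold higher number from compound 1 to compound 4 (0.29 log units; within the scatter); a 2.0-fold lower number from compound 2 to compound 4 (0.30 log units; within the scatter)), so compound 4 cannot be separated from any of the three earlier compounds, although compound 2 and compound 1 are separated from each other. No measurement to hand offers an explanation for this result.

Open, from the compounds shown here alone, is what the two methyl groups contribute, which an unsubstituted pyrrol-1-yl group would test. Also open, going by these compounds, is how a saturated piperidin-1-yl ring or an imidazol-1-yl ring would read in this assay.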